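The source may report more compounds than this note shows. Statements on the series, on what has been measured and on what is new or still open speak of the compounds shown alone.

Compound 1 `CCOC(=O)c1c(-c2cccc(F)c2)[nH]c2cc(OC)c(F)cc2c1=O`: in an ADME assay on Raji cells (Homo sapiens) for cytotoxicity, read by luminescence, with a stated time of 72 h (on this read-out higher numbers stand for an effect only at larger amounts of compound and lower numbers for an effect already at smaller amounts), compound 1 gives > 21500 nM, which is a limit of the assay rather than a number.
Compound 2 `CCOC(=O)c1c(-c2cccc(Br)c2)[nH]c2cc(OC)c(F)cc2c1=O`: in this assay compound 2 gives > 21500 nM, again a limit rather than a number.

Compound 2 therefore stands only at a limit, with no number of its own; both values shown sit at the limit of > 21500 nM in this assay, at which 2 of the 2 values shown sit. Going by the values given here, the one step between measured compounds, a step that the two limits leave unreadable from compound 1 to compound 2, cannot be read because the limit of > 21500 nM in this assay, at which 2 of the 2 values shown sit, hides both ends of it. Compound 3 `CCOC(=O)c1c(-c2cccc(Oc3c(C)cccc3C)c2)[nH]c2cc(OC)c(F)cc2c1=O` differs from compound 2 by 2,6-dimethylphenoxy in place of bromo on an aromatic carbon. Among the compounds with values here, no measured step bears on this change, so no direction or size can be drawn from the data; a further limit is the most likely outcome. Compound 3 is estimated at 25000 nM, within 8000 nM to 60000 nM, an expected step that the limit leaves unreadable from compound 2 to compound 3 in this assay.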

Compound 3, half-maximal effective concentration: > 21500 nM
Compound 3: a limit, no number (the forecaster's own chance of this, stated with the estimate: 70%); the middle value lies beyond the limit too.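

With compound 3 also giving only a limit of the assay rather than a number, no step among compound 1, compound 2 and compound 3 can be read, as all three values stop at the same point: the limit of > 21500 nM in this assay, at which 3 of the 3 values shown sit.

Going by these compounds, whether compound 1, compound 2 and compound 3 truly differ in this assay stays open, as does how far past that limit each one lies.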